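The source may hold more compounds than are shown below. What is called first, only, known or untested is meant among the compounds shown, and "the series" means these compounds.

For the measured compounds named here, in an ADME assay on microsomes from liver (Mus musculus) for metabolic stability, read by LC-MS, using NADPH, with a stated time of 10 min, tested at 10 uM (a lower number here means that the compound disappears faster, a higher number that the compound lasts longer), compound 3 (`CO[C@H]1CC[C@@H](n2nc(Oc3cc(C(F)(F)F)ccn3)c3c(N)ncnc32)CC1`) gives 0.0333 h, the lowest number so far, against compound 1 (`N#Cc1ccnc(Oc2nn(C3CCC3)c3ncnc(N)c23)c1`) at 0.4 h and compound 2 (`Nc1ncnc2c1c(Oc1cc(C(F)(F)F)ccn1)nn2[C@H]1CC[C@@H](N)CC1`) at 0.917 h. Compound 4 (`CO[C@H]1CC[C@H](n2nc(Oc3cc(C(F)(F)F)ccn3)c3c(N)ncnc32)CC1`) has the same atoms and bonds as compound 3: the two compounds have the same atoms and bonds and differ only in configuration as drawn: 2 of 2 stereo elements differ (all stereocentres are inverted: mirror images); a stereocentre at a saturated ring carbon is drawn s in compound 3 and r in compound 4; a stereocentre at a saturated ring carbon is drawn s in compound 3 and r in compound 4. Going by the values given here, the only measured step is a 28-fold lower number from compound 2 to compound 3 (1.44 log units; beyond the scatter), a large one, but it exchanges a group on the saturated ring and says nothing about configuration. Among the compounds with values here, no measured pair isolates a change of configuration, so no shift beyond the scatter is expected in this assay. The expected step is a 1.5-fold higher number from compound 3 to compound 4 (0.18 log units; within the scatter), which stays within the scatter. For compound 4 the estimated half-life is 0.05 h, with an expected range from 0.02 h to 0.2 h.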

Compound 4, half-life: 0.217 h
Compound 4: the middle estimate sits 4.3-fold (0.64 log units) below what was measured, outside the stated range (above it).
By their numbers in this assay, from the lowest: compound 3; then compounds 4 and 1 (each within the scatter of the next); then compound 2.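

In this assay, configuration on the saturated ring is a lever in its own right, giving a 6.5-fold higher number from compound 3 to compound 4 (0.81 log units; beyond the scatter) and moving the number beyond the scatter. That shift can be assigned to configuration alone because nothing else separates the pair: the fact that compounds 3 and 4 differ only in the configuration as drawn. The methoxy compounds still fall short of the amine, with a 4.2-fold lower number from compound 2 to compound 4 (0.63 log units; beyond the scatter) in this configuration, a smaller loss than a 28-fold lower number from compound 2 to compound 3 (1.44 log units; beyond the scatter) in the other.

From the compounds shown here alone, whether configuration shifts the number to the same extent with an amino group, or with a hydroxyl or a carboxylic acid, on the saturated ring remains open.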